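A few compounds are considered here, and "the series" means these few. Any claim that something is new, unique, unknown or untested is made for them only; others in the source may bear on it.

In an ADME assay on a cell-free system (plasma, Homo sapiens) for metabolic stability, read by LC-MS (a lower number here means that the compound disappears faster, a higher number that the compound lasts longer), compound 2 `NCc1ccc(C(=O)Nc2ccncc2F)cc1-c1cccc(NC(=O)c2cc(C(=O)O)ccc2F)c1` gives > 2 h, which is a limit and not a number. It is the only one of the three measured compounds with a free carboxy group, and the other two are esters. Compound 4 `COC(=O)c1ccc(F)c(C(=O)Nc2cccc(-c3cc(C(=O)Nc4ccncc4F)ccc3CN)c2)c1` differs from it in one place, methyl in place of hydrogen on an oxygen next to a carbonyl group, which reads as carboxy to methoxycarbonyl.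

For the measured compounds named here, no measured step covers this change directly, and the two measured esters also differ from compound 4 elsewhere in the molecule. Compound 1 `CCCCOC(=O)c1cccc(NC(=O)c2cccc(-c3cc(C(=O)Nc4ccncc4F)ccc3CN)c2)c1`, the butyl ester, gives < 0.0834 h, which is also a limit. Compound 3 `CCC(C)OC(=O)c1cccc(NC(=O)c2cccc(-c3cc(C(=O)Nc4ccncc4F)ccc3CN)c2)c1`, the sec-butyl ester, gives 0.267 h. The step of an at least 3.2-fold higher number from compound 1 to compound 3 (0.50 log units; beyond the scatter) comes with sec-butyl in place of butyl on an oxygen next to a carbonyl group, so the two esters are not equal, yet both read well short of compound 2.

Compound 4 is therefore expected to resemble these esters, with compound 3 at 0.267 h as the closest numerical guide. The expected change is an at least 8.0-fold lower number from compound 2 to compound 4 (0.90 log units; beyond the scatter), towards faster disappearance and well beyond the scatter. For compound 4 the estimated half-life is 0.25 h, with an expected range of 0.08 h to 0.8 h.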

Compound 4, half-life: 0.883 h
Estimate against measurement, compound 4: 3.5-fold (0.55 log units) below, and the stated range ends below it.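

In this assay, the change gives an at least 2.2-fold lower number from compound 2 to compound 4 (0.35 log units; beyond the scatter), and this is the first pair shown that sets a free carboxy group against an ester while differing in one place only, with methyl in place of hydrogen on an oxygen next to a carbonyl group. The step shows that turning 5-carboxy-2-fluorophenyl into 2-fluoro-5-(methoxycarbonyl)phenyl shortens the half-life beyond the scatter, although compound 4, at 0.883 h, still gives a true number and not a limit of the assay. The full size of the step cannot be read, however, because compound 2 stands at a limit of the assay: the limit of > 2 h in this assay, at which 1 of the 4 values shown sits.

The compounds shown leave open how an ethyl or a butyl chain on this same oxygen would read, and whether the gain seen from butyl to sec-butyl on the esters without fluorine would carry over to this fluorinated ring. For the compounds shown here, they also leave open how an amide in place of the methoxycarbonyl group would read in this assay, and what the fluorine contributes, since no pair here differs in that atom alone.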